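Removing the Nitrile: What Compound 3 Should Show

This account rests on a few compounds, and the source may have more. Where it says the series, first, only, none or still open, it means among the compounds named here.

Compound 1 `CC1(C)[C@H]2CC[C@]1(C)N(Cc1cn(-c3cccc(F)c3)nn1)C(=O)C2` and compound 2 `CC1(C)[C@H]2CC[C@]1(C)N(Cc1cn(-c3cccc(C#N)c3)nn1)C(=O)C2` share one core and differ only in the group on the aromatic ring. In a functional assay on PANC-1 cells (Homo sapiens) for inhibition, read by MTT assay, with a stated time of 24 h (on this read-out higher numbers stand for weaker inhibition and lower numbers for stronger inhibition), compound 1 gives 220 nM, and compound 2 gives 260 nM. Compound 2 stands at the higher of the two numbers, though a 1.2-fold higher number from compound 1 to compound 2 (0.07 log units; within the scatter) is within the scatter. Compound 3 `CC1(C)[C@H]2CC[C@]1(C)N(Cc1cn(-c3ccccc3)nn1)C(=O)C2` carries the change (hydrogen in place of cyano on an aromatic carbon). Within the data shown here, the only measured step that bears on this is a 1.2-fold higher number from compound 1 to compound 2 (0.07 log units; within the scatter), which was small, so no step beyond the scatter is expected in this assay. Compound 3 is therefore estimated at 230 nM, between 110 nM and 500 nM, an expected step of a 1.1-fold lower number from compound 2 to compound 3 (0.05 log units; within the scatter).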

Compound 3, half-maximal inhibitory concentration: 160 nM
Estimate against measurement, compound 3: 1.4-fold (0.16 log units) above; the measured number falls inside the stated range.
By their numbers in this assay, from the lowest: compounds 3, 1 and 2 (each within the scatter of the next).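

In this assay, the plain phenyl gives this position a reference point, with a 1.6-fold lower number from compound 2 to compound 3 (0.21 log units; within the scatter) and a 1.4-fold lower number from compound 1 to compound 3 (0.14 log units; within the scatter) as the steps to hydrogen. Both steps stay within the scatter, so hydrogen, fluoro and cyano at this place on the ring cannot be told apart in these three compounds. Nothing available accounts for why they read alike. From the compounds shown here alone, whether an amine or a carboxylic acid at this place would also stay within the scatter remains open, as does whether a longer chain would.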